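Chloro for Trifluoromethyl: Estimating Compound 4

The compounds below may be only part of what the source reports. "The series", "measured", "known", "first", "only" and "open" are said of these compounds alone.

Measured so far, in a functional assay on MCF7 cells (Homo sapiens) for inhibition, read by MTT assay, with a stated time of 72 h; a lower number here means a stronger inhibitor, a higher number a weaker inhibitor:
- Compound 1, `COc1cc(NC(C)CCCNC(=O)NNC(=O)Nc2cccc(F)c2)c2ncccc2c1`: compound 1 gives 150 nM
- Compound 2, `COc1cc(NC(C)CCCNC(=O)Nc2ccc(C(F)(F)F)cc2)c2ncccc2c1`: compound 2 gives 1900 nM
- Compound 3, `COc1cc(NC(C)CCCNC(=O)NNC(=O)Nc2ccc(C(F)(F)F)cc2)c2ncccc2c1`: compound 3 gives 100 nM

Compound 3 has the lowest number of the three, but its neighbour compound 1 sits within the scatter of it, so the two cannot be ranked; only compound 2 stands clearly apart, with a much higher number. Two steps are known. The step of a 13-fold higher number from compound 1 to compound 2 (1.10 log units; beyond the scatter) was large, but it changed the linker, not the ring substituent. The step of a 1.5-fold lower number from compound 1 to compound 3 (0.18 log units; within the scatter) changed the substituent on the outer ring and stayed within the scatter.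

Compound 4, `COc1cc(NC(C)CCCNC(=O)NNC(=O)Nc2ccc(Cl)cc2)c2ncccc2c1`, differs from compound 3 by chloro in place of trifluoromethyl on an aromatic carbon. This resembles the kind of change seen in the step from compound 1 to compound 3, which barely moved the number, so little movement is expected in this assay. Compound 4 is therefore estimated at 150 nM, with a range from 50 nM to 450 nM. That estimate corresponds to an expected step of a 1.5-fold higher number from compound 3 to compound 4 (0.18 log units; within the scatter).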

Compound 4, half-maximal inhibitory concentration: 180 nM
Compound 4: the middle estimate sits 1.2-fold (0.08 log units) below what was measured, within the range that was stated.
By their numbers in this assay, from the lowest: compounds 3, 1 and 4 (each within the scatter of the next); then compound 2.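

In this assay, chloro, a single heavy atom, can take the place of the four heavy atoms of trifluoromethyl on this aromatic carbon with no difference that can be read, as a 1.8-fold higher number from compound 3 to compound 4 (0.26 log units; within the scatter) shows. The step of a 1.2-fold higher number from compound 1 to compound 4 (0.08 log units; within the scatter) likewise leaves compound 4 level with the 3-fluorophenyl compound, whereas an 11-fold lower number from compound 2 to compound 4 (1.02 log units; beyond the scatter) keeps a large gap, so among these four compounds the carbamoylamino group, present in all but compound 2, marks the low numbers and the three aromatic substituents cannot be separated. Nothing measured here explains these results.

Still open, going by these compounds, is whether a far different group on this ring carbon, such as an amine or a carboxylic acid, would keep the number this low. Also open, on these data alone, is whether chloro would behave the same way on the shorter chain of compound 2.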